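The source may hold more compounds than are shown below. What is called first, only, known or untested is meant among the compounds shown, and "the series" means these compounds.

Measured so far in a functional assay on HEK293 cells for agonist activity at Vasopressin V2 receptor (Homo sapiens), read by a luciferase reporter and cAMP accumulation; on this read-out higher numbers stand for an effect only at larger amounts of compound and lower numbers for an effect already at smaller amounts:
compound 1 `Cc1cc(C(=O)N2CCCCc3ccccc32)ccc1CNC(=O)Nc1c(F)cccc1F` — 2.1 nM
compound 2 `Cc1cc(C(=O)N2CCCCc3ccccc32)ccc1CNC(=O)NCC(=O)N(C)C` — 58 nM
compound 3 `Cc1cc(C(=O)N2CCCCc3ccccc32)ccc1CNC(=O)NCC(=O)N1CCCC1` — 100 nM

Compound 1 stands lowest of the three numbers; compound 2 is nearest to it and compound 3 furthest. Compound 4 `Cc1cc(C(=O)N2CCCCc3ccccc32)ccc1CNC(=O)NCC(=O)N1CCCCC1` is not yet measured. Relative to compound 1 its change is ((piperidin-1-yl)carbonyl)methyl in place of 2,6-difluorophenyl on an amide-type nitrogen.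

Within the data shown here, two measured steps bear on this: a 28-fold higher number from compound 1 to compound 2 (1.44 log units; beyond the scatter) and a 48-fold higher number from compound 1 to compound 3 (1.68 log units; beyond the scatter), each a large rise in the number once a carbamoylmethyl-type group replaces the 2,6-difluorophenyl on the amide-type nitrogen. The further step a 1.7-fold higher number from compound 2 to compound 3 (0.24 log units; within the scatter) stays within the scatter, so the choice of the amine on the carbonyl carbon has not shifted the number noticeably so far. The ((piperidin-1-yl)carbonyl)methyl group of compound 4 belongs to the same family as those of compounds 2 and 3, so a step of similar size in the same direction is expected, roughly a 57-fold higher number from compound 1 to compound 4 (1.76 log units; beyond the scatter). For compound 4 the estimate in this assay is 120 nM, with a range from 40 nM to 350 nM.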

Compound 4, half-maximal effective concentration: 150 nM
Estimate against measurement, compound 4: 1.3-fold (0.10 log units) below, and the stated range covers the measured number.
By their numbers in this assay, from the lowest: compound 1; then compounds 2, 3 and 4 (each within the scatter of the next, the first and the last beyond it).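

In this assay, a third amide-bearing group, ((piperidin-1-yl)carbonyl)methyl, gives a large step when it replaces 2,6-difluorophenyl on the amide-type nitrogen (a 71-fold higher number from compound 1 to compound 4 (1.85 log units; beyond the scatter)), so the rise now holds across compounds 2, 3 and 4. The amine on the carbonyl carbon also shows its first step beyond the scatter (a 2.6-fold higher number from compound 2 to compound 4 (0.41 log units; beyond the scatter)), whereas the other step to compound 4 stays within it (a 1.5-fold higher number from compound 3 to compound 4 (0.18 log units; within the scatter)), so this position separates only piperidin-1-yl from dimethylamino, and only modestly. The data at hand offer no explanation for either step.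

Going by these compounds, it remains open how morpholin-4-yl or a free primary amide would behave on the carbonyl carbon. It is also unclear whether plain phenyl or a longer chain on the amide-type nitrogen would stay close to compound 1 or close to compounds 2, 3 and 4.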